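The compounds below may be only part of what the source reports. "The series", "measured", "known", "first", "only" and "open" are said of these compounds alone.

Two compounds were tested in an assay on isolated protein for inhibition of Rho-associated protein kinase 2 (Homo sapiens), read by scintillation counting, radiometric assay and 33P incorporation, with a stated time of 40 min, in the presence of a further agent that is not named here; on this read-out higher numbers stand for weaker inhibition and lower numbers for stronger inhibition. Compound 1 `CC(=O)Nc1cccc(NC(=O)COc2ccc3c(=O)ccoc3c2)c1` gives 136 nM. Within the data shown here, compound 2 `CCc1ccc(C(=O)Nc2cccc(NC(=O)COc3ccc4c(=O)ccoc4c3)c2)cc1` gives 24 nM, the lower of the two numbers; the single measured step, a 5.7-fold lower number from compound 1 to compound 2 (0.75 log units; beyond the scatter), puts 4-ethylphenyl in place of methyl on a carbonyl carbon. Compound 3 `CCCc1ccc(C(=O)Nc2cccc(NC(=O)COc3ccc4c(=O)ccoc4c3)c2)cc1` has not been measured. It differs from compound 2 by methyl in place of hydrogen on a saturated chain carbon, two bonds along the chain from an aromatic carbon. Among the measured compounds shown here, no measured step touches this chain, and the one step that is known exchanges a whole ring for a methyl, a far larger change than adding a single carbon to the chain. The expectation is therefore a step of about a 1.1-fold lower number from compound 2 to compound 3 (0.04 log units; within the scatter), within the scatter. Compound 3 is estimated at 22 nM, with a likely range from 9 nM to 55 nM.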

Compound 3, half-maximal inhibitory concentration: 14 nM
Compound 3: middle estimate off by 1.6-fold (0.20 log units), on the high side; low and high end bracket the measured number.
By their numbers in this assay, from the lowest: compounds 3 and 2 (each within the scatter of the next); then compound 1.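

Extending the chain from 4-ethylphenyl to 4-propylphenyl gives a 1.7-fold lower number from compound 2 to compound 3 (0.23 log units; within the scatter) in this assay, so at this position on a saturated chain carbon the added methyl leaves the number within normal measurement variation. Set against the small acetyl end of compound 1, 4-propylphenyl at that place gives a 9.7-fold lower number from compound 1 to compound 3 (0.99 log units; beyond the scatter) and so, like 4-ethylphenyl, stands apart from compound 1 beyond the scatter. No evidence is available here to explain either step.

The compounds shown do not tell how far this tolerance extends, for instance to a butyl or longer chain on the ring. They also leave open whether an amine or a carboxylic acid at the end of the chain would fit as well as propyl does.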